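A para-phenyl replacing hydroxy on the hydrazone aryl ring

This account rests on a few compounds, and the source may have more. Where it says the series, first, only, none or still open, it means among the compounds named here.

Three compounds share one core, differing only in the aryl group on the amine nitrogen: compound 1 `CC1CC/C(=N\Nc2cccc(Cl)c2)c2ncc(C(=O)O)c(=O)n21`, compound 2 `CC1CC/C(=N\Nc2ccccc2O)c2ncc(C(=O)O)c(=O)n21` and compound 3 `CC1CC/C(=N\Nc2ccc(O)cc2)c2ncc(C(=O)O)c(=O)n21`. In a functional assay on the whole organism for inhibition, with Rattus norvegicus as the target (a lower number here means that less compound is needed, a higher number that more compound is needed for the effect), compound 1 gives only a limit, > 100 umol/kg. In this assay compound 2 likewise reaches only a limit, > 100 umol/kg. Compound 3 stands at the same place in this assay, with only a limit, > 100 umol/kg. All three values sit at the limit of > 100 umol/kg in this assay, at which 3 of the 3 values shown sit, so the steps a step that the two limits leave unreadable from compound 1 to compound 2, a step that the two limits leave unreadable from compound 1 to compound 3 and a step that the two limits leave unreadable from compound 2 to compound 3 cannot be read.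

Compound 4 `CC1CC/C(=N\Nc2ccc(-c3ccccc3)cc2)c2ncc(C(=O)O)c(=O)n21` differs from compound 3 by phenyl in place of hydroxy on an aromatic carbon. Going by the values given here, no measured step bears on this change, and nothing among the three compounds shows where a reading away from the limit might arise. The expected step is a step that the limit leaves unreadable from compound 3 to compound 4. Compound 4 is therefore estimated in this assay at 150 umol/kg, with a range from 30 umol/kg to 1000 umol/kg, and a limit rather than a number is the more probable outcome.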

Compound 4, dose for 50% inhibition: > 100 umol/kg
Compound 4 ended at the assay's limit; the forecaster's own chance of this, stated with the estimate: 70%; the middle value lies beyond the limit too.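

In this assay compound 4 gives only a limit, > 100 umol/kg, so the step from compound 3 to compound 4 cannot be read. The compounds shown leave open whether any aryl group on the amine nitrogen of the shared core gives a reading away from the limit: the limit of > 100 umol/kg in this assay, at which 4 of the 4 values shown sit.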